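From oxan-4-yl to 2-(oxan-4-yl)ethyl on the shared core

The source may hold more compounds than are shown below. What is called first, only, known or untested is meant among the compounds shown, and "the series" means these compounds.

In an ADME assay on S9 fraction from liver (Rattus norvegicus) for metabolic stability, with a stated time of 1 h (a higher number here means that more of the compound is left, a lower number that less of the compound is left), compound 3 `N#Cc1cnc(NCc2cnccc2C(F)(F)F)cc1NC1CCOCC1` gives 17% and stands level, within the scatter, with compound 2 `N#Cc1cnc(NCc2cnccc2C(F)(F)F)cc1N[C@H]1CC[C@H](O)CC1` at 25% while clearly ahead of compound 1 `N#Cc1cnc(NCc2cnccc2C(F)(F)F)cc1N[C@H]1CC[C@@H](O)CC1` at 6% on these numbers. Compound 4 `N#Cc1cnc(NCc2cnccc2C(F)(F)F)cc1NCCC1CCOCC1` keeps the shared core and alters only the group on the nitrogen: 2-(oxan-4-yl)ethyl in place of oxan-4-yl on a nitrogen on an aromatic ring gives 2-(oxan-4-yl)ethyl in place of oxan-4-yl on a nitrogen on an aromatic ring.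

Within the data shown here, no measured step covers this exact change. The closest evidence comes from other replacements at the same nitrogen, which gave a number 11 percentage points higher from compound 1 to compound 3 (beyond the scatter) and a number 8 percentage points lower from compound 2 to compound 3 (within the scatter) as their results. The first of these is modest and the second lies within the scatter. A modest a number 19 percentage points higher from compound 1 to compound 2 (beyond the scatter) also shows how far this read-out can move, and that step arises from the fact that compounds 1 and 2 differ only in the configuration as drawn alone. On those sizes, no step beyond the scatter is the likeliest outcome in this assay and a modest step is the most that is expected, with only a tentative lean lower. The expected change is a number 5 percentage points lower from compound 3 to compound 4 (within the scatter) on this estimate. Compound 4 is estimated at 12% with an expected range from 3% to 27% in this read-out.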

Compound 4, percent of the compound remaining: 0%
The estimate for compound 4 lay 12 percentage points above the measured number; measured number below the stated range.
By their numbers in this assay, from the lowest: compounds 4 and 1 (each within the scatter of the next); then compounds 3 and 2 (each within the scatter of the next).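

In this assay, 2-(oxan-4-yl)ethyl in place of oxan-4-yl on the nitrogen gave a number 17 percentage points lower from compound 3 to compound 4 (beyond the scatter) and so showed that keeping the same ring does not keep the result once the ethyl chain is inserted, a change the earlier replacements at this nitrogen had not covered. Against the 4-hydroxycyclohexyl compounds the same group gave a number 25 percentage points lower from compound 2 to compound 4 (beyond the scatter) but a number 6 percentage points lower from compound 1 to compound 4 (within the scatter) and so leaves compound 4 level with compound 1, which means that this position reaches the low end of the values shown through a longer group as well as through the configuration as drawn. The information at hand concerns configuration alone, which plays no part in this change, and so offers no cause for the result.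

The compounds shown leave open where oxan-4-ylmethyl, with its shorter chain, would fall between compound 3 and compound 4, and whether a longer chain could fall any differently. They also leave open whether an amine such as piperidin-4-yl in place of the oxan-4-yl ring would behave like compound 3 in this assay.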